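This account rests on a few compounds, and the source may have more. Where it says the series, first, only, none or still open, it means among the compounds named here.

In a toxicity assay on THP-1 cells (Homo sapiens) for inhibition (on this read-out higher numbers stand for lower toxicity in this test and lower numbers for higher toxicity in this test), compound 1 `Cn1c(-c2cccc(C#N)c2)cnc1NC(=O)c1ncc[nH]1` gives > 50000 nM, which is a limit of the assay rather than a number. Compound 2 `COc1ccc(-c2cnc(NC(=O)c3ccc(F)cc3)n2C(C)C)cc1` likewise gives only a limit, > 50000 nM. Compound 3 `O=C(Nc1ncc(-c2ccccc2)o1)c1ccc(F)cc1` gives 17000 nM. Compound 2 therefore stands at the limit of > 50000 nM in this assay, at which 2 of the 3 values shown sit, and no measured step between two compounds that differ in one place is shown. Compound 4 `COc1ccc(-c2cnc(NC(=O)c3ccc(F)cc3)n2-c2ccccc2)cc1` differs from compound 2 by phenyl in place of isopropyl on an aromatic nitrogen. For the measured compounds named here, with no measured step bearing on this change, the expected step in this assay is a number no higher from compound 2 to compound 4 (the limit leaves the size open), none beyond the usual scatter. Compound 4 is estimated at 50000 nM, within a range from 20000 nM to 100000 nM, and it may well return only a limit again.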

Compound 4, half-maximal cytotoxic concentration: 8800 nM
Compound 4: the middle estimate sits 5.7-fold (0.75 log units) above what was measured; the whole stated range lies above it.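

For the compounds shown here, on the aromatic nitrogen, this assay now registers a change where the earlier compounds showed no measured step: phenyl in place of isopropyl gives an at least 5.6-fold lower number from compound 2 to compound 4 (0.75 log units; beyond the scatter), so the lower number here stands for higher toxicity in this test. The size of this step remains open at its upper end because compound 2 carries only a limit of the assay: the limit of > 50000 nM in this assay, at which 2 of the 4 values shown sit.

The compounds shown leave open whether the aromatic ring of the phenyl is what matters here. They also leave open how a benzyl group or a longer chain on this nitrogen would read out.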